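The compounds below may be only part of what the source reports. "The series", "measured", "known", "first", "only" and "open" are said of these compounds alone.

Two compounds share a core in which a phenyl ring carries, at one side, a thiazolidinedione ring joined through a double bond and, at the other side, an ether link to an acetamide. Compound 1 `Cc1cccc(NC(=O)COc2ccc(/C=C3\SC(=O)NC3=O)cc2)n1` carries a 6-methylpyridin-2-yl group on the amide nitrogen, and in a functional assay on PC-3 cells (Homo sapiens) for inhibition (on this read-out lower numbers stand for stronger inhibition of growth and higher numbers for weaker inhibition of growth), compound 1 gives 58300 nM. Compound 2 `O=C(COc1ccc(/C=C2\SC(=O)NC2=O)cc1)Nc1ccc(Br)cc1` carries a 4-bromophenyl group at the same place, and in this assay compound 2 gives 86600 nM. The step between them is a 1.5-fold higher number from compound 1 to compound 2 (0.17 log units; within the scatter), so the two measured compounds sit within the usual scatter of one another, and compound 2 stands alongside compound 1 rather than apart from it.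

Compound 3 `O=C(COc1ccc(/C=C2\SC(=O)NC2=O)cc1)Nc1ccc(F)cc1F` has not yet been measured. It differs from compound 2 in one place: 2,4-difluorophenyl in place of 4-bromophenyl on an amide-type nitrogen. Going by the values given here, the only measured step touching this place, the one from compound 1 to compound 2, exchanged one aromatic ring on the amide nitrogen for another and stayed within the scatter. On that basis the step of a 1.1-fold lower number from compound 2 to compound 3 (0.03 log units; within the scatter) is expected to be small, with no direction beyond the scatter. Compound 3 is therefore estimated at 80000 nM in this assay, within a range of 35000 nM to 180000 nM.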

Compound 3, concentration for 50% growth inhibition: > 100000 nM
Compound 3: no number, only a limit; the forecaster's own chance of this, stated with the estimate: 25%; at least 1.2-fold (0.09 log units) between middle value and limit.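

Compound 3 gives no number in this assay, only a limit of the assay: the limit of > 100000 nM in this assay, at which 1 of the 3 values shown sits. Read as floors, the limit gives an at least 1.1-fold higher number from compound 2 to compound 3 (0.06 log units; that floor lies within the scatter), and an at least 1.7-fold higher number from compound 1 to compound 3 (0.23 log units; that floor lies within the scatter). So this position has now taken a third aromatic group, the first with fluorine on it, and 2,4-difluorophenyl on the amide-type nitrogen shows no stronger inhibition of growth than 4-bromophenyl or 6-methylpyridin-2-yl, while the real size of the change could be anything from within the scatter to well beyond it.

As far as these compounds go, how far the true value of compound 3 lies past the limit stays open, and with it whether this change matters at all or only appears small because the assay stops there. Also open, from the compounds shown here alone, is whether anything placed at this position can lower the number, such as an amine or a carboxylic acid on the aromatic ring, or a longer chain on the amide nitrogen in place of the directly attached ring.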